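Ethoxy for (ethylsulfanyl)methyl on a core that shows only limits

This account rests on a few compounds, and the source may have more. Where it says the series, first, only, none or still open, it means among the compounds named here.

Compound 1 `CCSCCC12CCC(c3nnc(-c4ccccc4C(F)(F)F)n3C)(CC1)CC2`: in an assay on CHO-K1 cells for inhibition of 11-beta-hydroxysteroid dehydrogenase type 2 (Homo sapiens), read by scintillation proximity assay (a higher number here means a weaker inhibitor, a lower number a stronger inhibitor), compound 1 gives > 4000 nM, a limit of the assay.
Compound 2 `Cn1c(-c2ccccc2C(F)(F)F)nnc1C12CCC(CNS(C)(=O)=O)(CC1)CC2`: in this assay compound 2 gives > 4000 nM, also a limit.
Compound 3 `Cn1c(-c2ccccc2C(F)(F)F)nnc1C12CCC(CCCC(C)(F)F)(CC1)CC2`: in this assay compound 3 gives > 4000 nM, again a limit.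

Compound 1 stands nowhere in particular among these numbers, since every value shown is a limit rather than a measured number; (the limit of > 4000 nM in this assay, at which 3 of the 3 values shown sit). The three changes that join the measured compounds, a step that the two limits leave unreadable from compound 1 to compound 2, a step that the two limits leave unreadable from compound 1 to compound 3 and a step that the two limits leave unreadable from compound 2 to compound 3, cannot be sized for the same reason.

Compound 4 `CCOCC12CCC(c3nnc(-c4ccccc4C(F)(F)F)n3C)(CC1)CC2` differs from compound 1 in one place: ethoxy in place of (ethylsulfanyl)methyl on a saturated chain carbon bound to a saturated ring carbon. Among the compounds with values here, the one measured step that starts from compound 1 at this very place, a step that the two limits leave unreadable from compound 1 to compound 2, gives no readable size, and neither does any other step, so there is no basis for expecting a change beyond the scatter in either direction. What the data do suggest is that compounds on this shared core tend to sit at the limit of this assay, and compound 4 is expected to do the same. The step that this estimate means, a step that the limit leaves unreadable from compound 1 to compound 4, is expected to stay within the scatter. Compound 4 is therefore estimated at 8000 nM, with a range from 3000 nM to 30000 nM.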

Compound 4, half-maximal inhibitory concentration: > 4000 nM
Compound 4: a limit, no number; the forecaster's own chance of this, stated with the estimate: 80%; the middle value lies beyond the limit too.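

In this assay compound 4 gives > 4000 nM, a limit and not a number. No step joining compound 4 to compound 1, compound 2 or compound 3 can be read, and all four compounds stay level with one another at the same limit: the limit of > 4000 nM in this assay, at which 4 of the 4 values shown sit.

The compounds shown leave open how far each lies beyond that limit, and whether any group at this place on the shared core gives a measurable value.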